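Methyl for Phenyl on a Ring Amide Carbonyl

This account rests on a few compounds, and the source may have more. Where it says the series, first, only, none or still open, it means among the compounds named here.

Compound 1 `NC(=O)c1c(NC(=O)c2ccc(Oc3ccccc3)cc2)sc2c1CCN(C(=O)c1ccccc1)C2` and compound 2 `CC(=O)N1CCc2c(sc(NC(=O)c3ccc(Oc4ccccc4)cc3)c2C(N)=O)C1` were compared in an ADME assay on RAW264.7 cells (Mus musculus) for cytotoxicity, read by MTT assay, with a stated time of 48 h, tested at 50 uM (a higher number here means more inhibition at the concentration tested (going by the name of the read-out), a lower number less inhibition), where compound 1 gives 4.71% and compound 2 gives 32.9%. The change between them is methyl in place of phenyl on a carbonyl carbon, and it made the step of a number 28.2 percentage points higher from compound 1 to compound 2 (beyond the scatter). Compound 3 `NC(=O)c1c(NC(=O)c2ccc(OCc3ccccc3)cc2)sc2c1CCN(C(=O)c1ccccc1)C2` differs from compound 1 in the shared core by benzyl in place of phenyl on an oxygen on an aromatic ring; in this assay compound 3 gives 13.7%, with the step of a number 9 percentage points higher from compound 1 to compound 3 (within the scatter). Compound 4 `CC(=O)N1CCc2c(sc(NC(=O)c3ccc(OCc4ccccc4)cc3)c2C(N)=O)C1` has not yet been measured. It differs from compound 3 by methyl in place of phenyl on a carbonyl carbon, the same change at the same place as the one between compound 1 and compound 2, a change that occurs twice among these four compounds. Because the earlier step was a number 28.2 percentage points higher from compound 1 to compound 2 (beyond the scatter), a step of about the same size is expected here, namely a number 24.3 percentage points higher from compound 3 to compound 4 (beyond the scatter). That expectation rests on a single pair, so the estimate is given a wide range. Compound 4 is therefore estimated at 38% in this assay, with a range from 20% to 58%.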

Compound 4, a percentage reported as inhibition, at one concentration (the size of the read-out at that concentration, not a potency): 11.6%
Beside the measured number, compound 4's estimate is 26.4 percentage points above it, outside the stated range (below it).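

In this assay, benzoyl to acetyl on the amide-type ring nitrogen gave a number 2.1 percentage points lower from compound 3 to compound 4 (within the scatter), so the step seen with phenyl on the oxygen did not carry over to the compounds with benzyl on that oxygen: the same change on two cores in this assay, a number 28.2 percentage points higher (beyond the scatter) from compound 1 to compound 2 and a number 2.1 percentage points lower (within the scatter) from compound 3 to compound 4, 30.3 percentage points apart, beyond the scatter of two such steps

The other change shows the same dependence, with benzyl in place of phenyl on the oxygen giving a number 21.3 percentage points lower from compound 2 to compound 4 (beyond the scatter) once acetyl is present: the same change on two cores in this assay, a number 9 percentage points higher (within the scatter) from compound 1 to compound 3 and a number 21.3 percentage points lower (beyond the scatter) from compound 2 to compound 4, 30.3 percentage points apart, beyond the scatter of two such steps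

Among these four compounds, the effect of each change therefore depends on the group at the other place, but each comparison rests on only two pairs at a single concentration, which shows neither why the steps differ nor how this change would behave on any other core.

The compounds shown leave open whether compound 2 is a lone case or whether other small groups on the carbonyl carbon, such as ethyl or a longer chain, would also depend on the group on the oxygen. They also leave open what an amine or a carboxylic acid on the terminal phenyl ring would do to either step.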